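Fluorinated aryl tails and passive permeability

The source may hold more compounds than are shown below. What is called first, only, known or untested is meant among the compounds shown, and "the series" means these compounds.

Measured so far, in a physicochemical assay for permeability, using PAMPA, with a stated time of 4 h, at pH 6.2, tested at 50 uM; on this read-out lower numbers stand for lower permeability and higher numbers for higher permeability:
compound 1 `O=C(O)CCCc1cn(CC(=O)O)c2c(/C=C/c3ccc(OCCCCc4c(F)ccc(F)c4F)cc3)cccc12` gives 1.4 10^-6 cm/s
compound 2 `Cc1c(CCCC(=O)O)c2cccc(/C=C/c3ccc(OCCCCc4ccccc4)cc3)c2n1CC(=O)O` gives 1.3 10^-6 cm/s
compound 3 `Cc1c(CCCC(=O)O)c2cccc(/C=C/c3ccc(OCCCCc4c(F)c(F)cc(F)c4F)cc3)c2n1CC(=O)O` gives 9.4 10^-6 cm/s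

Compound 2 has the lowest of the three numbers in this assay, though compound 1 sits within the scatter of it, and only compound 3 lies clearly beyond it. Compound 4 `Cc1c(CCCC(=O)O)c2cccc(/C=C/c3ccc(OCCCCc4c(F)ccc(F)c4F)cc3)c2n1CC(=O)O` differs from compound 2 in one place: 2,3,6-trifluorophenyl in place of phenyl on a saturated chain carbon, four bonds along the chain from an oxygen on an aromatic ring. Among the compounds with values here, one measured step bears on this change, a related substitution at the same place: a 7.2-fold higher number from compound 2 to compound 3 (0.86 log units; beyond the scatter). Against that, compound 1, which carries the same 2,3,6-trifluorophenyl on a different core, gives a number close to that of compound 2. A rise is therefore expected, but smaller than the step to compound 3; the estimated step is a 2.7-fold higher number from compound 2 to compound 4 (0.43 log units; beyond the scatter). Compound 4 is expected at 3.5 10^-6 cm/s, with a range from 1.2 10^-6 cm/s to 9.5 10^-6 cm/s.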

Compound 4, apparent permeability: 4.4 10^-6 cm/s
Estimate against measurement, compound 4: 1.3-fold (0.10 log units) below; low and high end bracket the measured number.
By their numbers in this assay, from the lowest: compounds 2 and 1 (each within the scatter of the next); then compound 4; then compound 3.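

In this assay, 2,3,6-trifluorophenyl in place of phenyl on the shared core also gives a clear rise (a 3.4-fold higher number from compound 2 to compound 4 (0.53 log units; beyond the scatter)), so the rise at this place is not confined to the 2,3,5,6-tetrafluorophenyl of compound 3. The two fluorinated tails also read apart, with hydrogen in place of fluoro on an aromatic carbon (a 2.1-fold lower number from compound 3 to compound 4 (0.33 log units; beyond the scatter)). With the tail held constant, methyl in place of hydrogen on an aromatic carbon of the core also moves the number (a 3.1-fold higher number from compound 1 to compound 4 (0.50 log units; beyond the scatter)), so the tail alone does not set it.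

No measurement at hand gives a cause for these steps. Open, on these data alone, is how a pyridine ring or a cyclohexyl group would read at this place, and how a longer chain would read.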